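The source may hold more compounds than are shown below. What is called first, only, known or untested is meant among the compounds shown, and "the series" means these compounds.

Values in a functional assay on HeLa cells (Homo sapiens) for cytotoxicity, read by sulforhodamine B assay; on this read-out higher numbers stand for weaker inhibition and lower numbers for stronger inhibition
- compound 1 `Cc1ccc(S(=O)(=O)NC(C2=CC(=O)c3c(O)ccc(O)c3C2=O)C(C)C)cc1` gives 4850 nM
- compound 2 `COc1ccc(S(=O)(=O)NC(C2=CC(=O)c3c(O)ccc(O)c3C2=O)C(C)C)cc1` gives 8950 nM
- compound 3 `CC(C)C(NS(=O)(=O)c1ccccc1Br)C1=CC(=O)c2c(O)ccc(O)c2C1=O` gives 8310 nM

Compound 3 stands within the scatter of both other compounds (a 1.1-fold lower number from compound 2 to compound 3 (0.03 log units; within the scatter); a 1.7-fold higher number from compound 1 to compound 3 (0.23 log units; within the scatter)). Compound 4 `CC(=O)c1ccc(S(=O)(=O)NC(C2=CC(=O)c3c(O)ccc(O)c3C2=O)C(C)C)cc1` carries 4-acetylphenyl in place of 2-bromophenyl on a sulfonyl sulfur. Those two steps are exchanges of the same group on the sulfonyl sulfur, and the remaining step (a 1.8-fold higher number from compound 1 to compound 2 (0.27 log units; within the scatter)) also stays within the scatter. Within the data shown here, no measured compound carries 4-acetylphenyl, and the evidence comes from only three compounds. No step beyond the scatter is therefore expected in this assay, and the estimated step is small (a 1.2-fold lower number from compound 3 to compound 4 (0.07 log units; within the scatter)). Compound 4 is expected at 7000 nM, with an estimated range of 3000 nM to 16000 nM.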

Compound 4, half-maximal inhibitory concentration: 3820 nM
Estimate against measurement, compound 4: 1.8-fold (0.26 log units) above, within the range that was stated.
By their numbers in this assay, from the lowest: compounds 4, 1, 3 and 2 (each within the scatter of the next, the first and the last beyond it).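

In this assay, among these compounds, the group on the sulfonyl sulfur now shifts the number beyond the scatter for the first time, though only modestly: 4-acetylphenyl against 2-bromophenyl (a 2.2-fold lower number from compound 3 to compound 4 (0.34 log units; beyond the scatter)) and acetyl against methoxy (a 2.3-fold lower number from compound 2 to compound 4 (0.37 log units; beyond the scatter)). Acetyl against methyl stays within it (a 1.3-fold lower number from compound 1 to compound 4 (0.10 log units; within the scatter)). This position therefore accepts acetyl with no weakening against any of the three earlier compounds.

No measurement shown accounts for these differences. As far as these compounds go, whether an amine or a carboxylic acid in place of acetyl on the aromatic carbon would widen this modest spread remains open.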